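A Second Methoxy Group on a Shared Amide Core

A few compounds are considered here, and "the series" means these few. Any claim that something is new, unique, unknown or untested is made for them only; others in the source may bear on it.

The set rests on compound 1 `O=C(CCc1cccc2c1B(O)OC2)Nc1cccc(-c2ccccc2)c1`, which in a functional assay on SK-OV-3 cells (Homo sapiens) for antiproliferative activity, read by MTT assay, with a stated time of 72 h (a higher number here means a weaker inhibitor, a lower number a stronger inhibitor), gives 250 nM. Compound 2 `COc1ccc(-c2cccc(NC(=O)CCc3cccc4c3B(O)OC4)c2)cc1` carries one more group, (methoxy in place of hydrogen on an aromatic carbon), and in this assay compound 2 gives 48 nM; the step recorded is a 5.2-fold lower number from compound 1 to compound 2 (0.72 log units; beyond the scatter). Compound 3 `COc1cccc(-c2cccc(NC(=O)CCc3cccc4c3COB4O)c2)c1` belongs to a second core, and the difference between the two cores is not broken down here. In this assay compound 3 gives 78000 nM, the highest number among the three measured compounds.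

Compound 4 `COc1cc(OC)cc(-c2cccc(NC(=O)CCc3cccc4c3COB4O)c2)c1` is not yet measured. It differs from compound 3 by methoxy in place of hydrogen on an aromatic carbon. This is the same kind of change as that from compound 1 to compound 2, but the surroundings differ: in compound 2 the new group sits para to a large group, whereas in compound 4 it sits meta to a large group and meta to a methoxy group, and the compound already holds a methoxy group before the change.

Among the compounds with values here, since the only measured instance of this kind of change is the step from compound 1 to compound 2, and compound 3 stands far from both with 78000 nM, the expected step for compound 4 is a 2.0-fold lower number from compound 3 to compound 4 (0.29 log units; within the scatter), smaller than that earlier one. In this assay compound 4 is therefore expected to give about 40000 nM, with a range from 8000 nM to 200000 nM.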

Compound 4, half-maximal inhibitory concentration: 88000 nM
Beside the measured number, compound 4's estimate is 2.2-fold (0.34 log units) below it; the range from low to high includes it.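

In this assay, the change from the 3-methoxyphenyl of compound 3 to the 3,5-dimethoxyphenyl of compound 4 gives a 1.1-fold higher number from compound 3 to compound 4 (0.05 log units; within the scatter), so the drop in the number seen on the core of compound 1 does not recur on this second core. Set side by side, the two instances show that this change does not carry over unaltered from one core to the other in this assay: the same change on two cores in this assay, a 5.2-fold lower number (0.72 log units; beyond the scatter) from compound 1 to compound 2 and a 1.1-fold higher number (0.05 log units; within the scatter) from compound 3 to compound 4, 5.9-fold (0.77 log units) apart, beyond the scatter of two such steps

Within the data shown here, this does not show that the core alone accounts for the gap, since there is only one pair on each core and compound 4 already holds a methoxy group before the change, unlike compound 1, and the new group also sits in a different place on the ring.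

The compounds shown leave open whether a single methoxy group placed as in compound 4 would behave differently on the core of compound 1, and whether a plain phenyl on the second core would stand close to compound 3. They also leave open whether a different group on the outer ring, such as an amine or a carboxylic acid, would shift the number on either core.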